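Lengthening an alkyne chain with a hydroxymethyl group

The compounds below may be only part of what the source reports. "The series", "measured", "known", "first", "only" and "open" are said of these compounds alone.

Measured compounds:
compound 1, `CCCC/C=C\c1cn([C@H]2C[C@H](O)[C@@H](CO)O2)c(=O)[nH]c1=O`, 361 ug/mL
compound 2, `CCC#Cc1cn([C@H]2C[C@H](O)[C@@H](CO)O2)c(=O)[nH]c1=O`, > 1000 ug/mL
compound 3, `CC(C)(C)C#Cc1cn(C2O[C@H](CO)[C@@H](O)[C@H]2O)c(=O)[nH]c1=O`, 300 ug/mL

In a functional assay on L1210 cells (Mus musculus) (a higher number here means a weaker inhibitor, a lower number a stronger inhibitor), compound 2 gives > 1000 ug/mL, which is a limit of the assay rather than a number (the limit of > 1000 ug/mL in this assay, at which 1 of the 3 values shown sits). Compound 4, `O=c1[nH]c(=O)n([C@H]2C[C@H](O)[C@@H](CO)O2)cc1C#CCCCO`, differs from compound 2 by hydroxymethyl in place of hydrogen on a saturated chain carbon, two bonds along the chain from a triple-bonded carbon. No measured step changes the alkyne chain in this way; the only step shown, an at least 2.7-fold higher number from compound 1 to compound 2 (0.44 log units; beyond the scatter), concerns a different change on the same aromatic carbon and gives no guide to adding a hydroxymethyl. With compound 2 at a limit, the step from compound 2 to compound 4 is expected to stay small, estimated as a number no higher from compound 2 to compound 4 (the limit leaves the size open). In this assay compound 4 is therefore expected near 1000 ug/mL, in the range 300 ug/mL to 3000 ug/mL.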

Compound 4, concentration for 50% inhibition: 280 ug/mL
Compound 4: middle estimate off by 3.6-fold (0.55 log units), on the high side; measured number below the stated range.
By their numbers in this assay, from the lowest: compounds 4, 3 and 1 (each within the scatter of the next). At a limit, above all of these: compound 2.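

In this assay, hydroxymethyl in place of hydrogen on the saturated chain gives an at least 3.5-fold lower number from compound 2 to compound 4 (0.55 log units; beyond the scatter), the only step shown that lengthens the alkyne chain. Going by these compounds, the full size of this step stays open because compound 2 gives a limit rather than a number: the limit of > 1000 ug/mL in this assay, at which 1 of the 4 values shown sits. The 5-hydroxypent-1-yn-1-yl chain and the hex-1-en-1-yl chain cannot be told apart, with a 1.3-fold lower number from compound 1 to compound 4 (0.11 log units; within the scatter).

The compounds shown leave open whether the hydroxyl or the extra chain length counts. A longer alkyne chain without the hydroxyl, or with an amine or a carboxylic acid in its place, would separate the two.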